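A few compounds are considered here, and "the series" means these few. Any claim that something is new, unique, unknown or untested is made for them only; others in the source may bear on it.

Working notes on the sulfonylurea series built on the shared core of compound 1 `CCCCCCCCC(C)S(=O)(=O)NC(=O)Nc1c(C(C)C)cccc1C(C)C`. For the measured compounds named here, in an assay on microsomes from liver for inhibition of sterol O-acyltransferase 1 (Rattus norvegicus) (a higher number here means a weaker inhibitor, a lower number a stronger inhibitor), compound 1 gives 1300 nM, the lowest of the three numbers so far. Compound 3 `CCCCCCCCCCCCS(=O)(=O)NC(=O)Nc1c(C(C)C)cccc1C(C)C`, with a longer unbranched chain on the sulfonyl, gives 3300 nM in this assay; compound 2 `CCCCCCCCC(c1ccccc1)S(=O)(=O)NC(=O)Nc1c(C(C)C)cccc1C(C)C` gives 9200 nM. Going by the values given here, the one single-point step measured, a 7.1-fold higher number from compound 1 to compound 2 (0.85 log units; beyond the scatter), concerns the group on the carbon bound to the sulfonyl sulfur and is therefore only loosely related to the change under study. Compound 3 differs from compound 1 in two places at once, so its number is read only as a value, not as a step.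

Compound 4 `CCCCCCCCCCCCCC(C)S(=O)(=O)NC(=O)Nc1c(C(C)C)cccc1C(C)C` carries pentyl in place of hydrogen on a saturated chain carbon, nine bonds along the chain from a sulfonyl sulfur, so the chain is extended far from the sulfonyl while the branch is kept. Among the compounds with values here, no measured step addresses chain extension alone. The values of compound 1 and compound 3 suggest that more chain does not lower the number, so a small rise in this assay is expected, with wide uncertainty. For compound 4 the expected step is a 1.9-fold higher number from compound 1 to compound 4 (0.28 log units; within the scatter). Compound 4 is therefore estimated at 2500 nM in this assay, in the range 1000 nM to 6500 nM.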

Compound 4, half-maximal inhibitory concentration: 830 nM
Estimate against measurement, compound 4: 3.0-fold (0.48 log units) above, and the stated range ends above it.
By their numbers in this assay, from the lowest: compounds 4 and 1 (each within the scatter of the next); then compound 3; then compound 2.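

Pentyl in place of hydrogen on a saturated chain carbon, nine bonds along the chain from a sulfonyl sulfur, leaves this assay unmoved within the scatter (a 1.6-fold lower number from compound 1 to compound 4 (0.19 log units; within the scatter)), so this position accepts the pentyl with no change that can be told from repeat measurement. For the compounds shown here, this is the first single-point step to address chain extension with the branch kept, and it contrasts with the phenyl in place of methyl on the chain carbon bound to the sulfonyl sulfur, the only other step, which lies beyond the scatter (a 7.1-fold higher number from compound 1 to compound 2 (0.85 log units; beyond the scatter)). Neither step can be taken as a trend, since each is a single change at its own place, and no measurement shown here accounts for the result.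

Going by these compounds alone, still open is whether a longer chain than the one in compound 4 stays level in this assay, or whether a shorter one such as propyl does the same. Also open, from the compounds shown here alone, is how a hydroxyl or a carboxylic acid would compare with the pentyl at this chain carbon.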